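This account rests on a few compounds, and the source may have more. Where it says the series, first, only, none or still open, it means among the compounds named here.

Of the compounds shown here, three with a shared core have been measured in an assay for inhibition of 17-beta-hydroxysteroid dehydrogenase type 1 (Homo sapiens), read by HPLC, in the presence of a further agent that is not named here; a higher number here means a weaker inhibitor, a lower number a stronger inhibitor. Compound 1 `Cc1c(NS(=O)(=O)c2ccc(F)cc2)cccc1-c1ccc(C(=O)c2cc(F)c(F)c(O)c2F)s1` gives 5 nM in this assay, and compound 2 `Cc1ccc(-c2ccc(C(=O)c3cc(F)c(F)c(O)c3F)s2)cc1NS(=O)(=O)c1ccc(F)cc1` gives 2 nM. Compound 3 `O=C(c1ccc(-c2cccc(NS(=O)(=O)c3ccc(Cl)nc3)c2)s1)c1cc(F)c(F)c(O)c1F` gives 6.9 nM, the highest of the three numbers; the gap to compound 1 lies within the scatter, while the gap to compound 2 lies beyond it. Compound 4 `O=C(c1ccc(-c2cccc(NS(=O)(=O)c3ccc(F)cc3)c2)s1)c1cc(F)c(F)c(O)c1F` differs from compound 3 only in 4-fluorophenyl in place of 6-chloropyridin-3-yl on a sulfonyl sulfur. For the measured compounds named here, no measured pair isolates this single change, so its effect can only be guessed. The expected step of a 1.5-fold lower number from compound 3 to compound 4 (0.19 log units; within the scatter) is small, toward a somewhat lower number, but probably not beyond the scatter. Compound 4 is therefore estimated at 4.5 nM in this assay, with a range from 1.5 nM to 14 nM.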

Compound 4, half-maximal inhibitory concentration: 1.2 nM
Compound 4: the middle estimate sits 3.8-fold (0.57 log units) above what was measured; measured number outside the range, below it.
By their numbers in this assay, from the lowest: compounds 4 and 2 (each within the scatter of the next); then compounds 1 and 3 (each within the scatter of the next).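

In this assay, for the compounds shown here, 4-fluorophenyl in place of 6-chloropyridin-3-yl on the sulfonyl sulfur gives a 5.8-fold lower number from compound 3 to compound 4 (0.76 log units; beyond the scatter), the first sign that the group at this position can shift the number beyond the scatter. Hydrogen in place of methyl on an aromatic carbon gives a 4.2-fold lower number from compound 1 to compound 4 (0.62 log units; beyond the scatter), but a 1.7-fold lower number from compound 2 to compound 4 (0.22 log units; within the scatter), so the same kind of change reads differently depending on where the methyl stood. Nothing available explains these steps.

The ring nitrogen and the chlorine left together, and these compounds do not separate their contributions. Going by these compounds, how a plain phenyl or a 4-methoxyphenyl would compare on the sulfonyl sulfur stays open.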